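Removing the methoxy from an indole vinyl sulfone

This account rests on a few compounds, and the source may have more. Where it says the series, first, only, none or still open, it means among the compounds named here.

Compound 2 `COc1ccc2[nH]c(-c3ccccc3)c(/C=C(\C#N)S(=O)(=O)c3ccccc3)c2c1` is a phenyl-substituted indole bearing a methoxy on its benzo ring and carrying a vinyl sulfone with a nitrile on the alkene. In a functional assay on SNB-19 cells (Homo sapiens) for inhibition, read by sulforhodamine B assay, with a stated time of 48 h (on this read-out lower numbers stand for stronger inhibition of growth and higher numbers for weaker inhibition of growth), compound 2 gives 13500 nM, the higher of the two numbers recorded. Its nearest neighbour is compound 1 `CC(=O)/C(=C\c1c(-c2ccccc2)[nH]c2ccccc12)S(=O)(=O)c1ccccc1`, which differs in more than one place, carrying an acetyl in place of the nitrile and no methoxy; in this assay compound 1 gives 6100 nM, a reading that lies beyond the scatter from that of compound 2. Among the compounds with values here, no single-change pair has been measured, so the effect of the methoxy on its own is not known from these two numbers.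

Compound 3 `N#C/C(=C\c1c(-c2ccccc2)[nH]c2ccccc12)S(=O)(=O)c1ccccc1` follows from compound 2 by one change: hydrogen in place of methoxy on an aromatic carbon. Within the data shown here, since no measured pair isolates this change, the direction cannot be read directly from the data. Compound 3 is expected to give a modestly lower number than compound 2, an estimated step of a 1.5-fold lower number from compound 2 to compound 3 (0.18 log units; within the scatter), within or near the scatter. For compound 3 the estimated value in this assay is 9000 nM, with a range from 3500 nM to 25000 nM.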

Compound 3, concentration for 50% growth inhibition: 8300 nM
Compound 3: middle estimate off by 1.1-fold (0.04 log units), on the high side; the measured number falls inside the stated range.
By their numbers in this assay, from the lowest: compounds 1, 3 and 2 (each within the scatter of the next, the first and the last beyond it).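

With compound 3, each of the two changes can be read on its own. In this assay, hydrogen in place of methoxy on the aromatic carbon gives a 1.6-fold lower number from compound 2 to compound 3 (0.21 log units; within the scatter), so at this position the read-out does not separate the methoxy compound from the unsubstituted one. Cyano in place of acetyl on the double-bonded chain carbon gives a 1.4-fold higher number from compound 1 to compound 3 (0.13 log units; within the scatter), so neither change, taken alone, moves the number beyond the scatter. No measurement is available that would explain these small steps.

Going by these compounds, it remains open whether this aromatic carbon would respond to other groups, such as a chlorine, a hydroxyl or an amine, given that methoxy and hydrogen read alike here. On these data alone, it is equally open whether a carboxylic acid or an ester on the double-bonded chain carbon would read like the nitrile and the acetyl, or whether a group such as a methyl in place of the phenyl on the sulfonyl sulfur would shift the number beyond the scatter.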